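The source may hold more compounds than are shown below. What is called first, only, known or untested is meant among the compounds shown, and "the series" means these compounds.

Compound 1 `Cc1cc(F)c(S(C)(=O)=O)cc1C(=O)N=C(N)N`: 44 nM
Compound 2 `CS(=O)(=O)c1cc(C(=O)N=C(N)N)c(F)cc1F`: 630 nM
Compound 3 `Cc1c(C(=O)N=C(N)N)cc(S(C)(=O)=O)c(Cl)c1Cl`: 29 nM

In a functional assay for inhibition of sodium/hydrogen exchanger (Oryctolagus cuniculus) (on this read-out lower numbers stand for stronger inhibition and higher numbers for weaker inhibition), compound 3 gives 29 nM, the lowest of the three numbers. Compound 1 gives 44 nM, which lies within the scatter of compound 3, so the two cannot be ranked. Compound 2 gives 630 nM, clearly beyond the scatter of compound 3. Among the compounds with values here, the only measured step between compounds differing in one place is a 14-fold higher number from compound 1 to compound 2 (1.16 log units; beyond the scatter), a large loss from a single exchange at an aromatic carbon.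

Compound 4 `Cc1c(C(=O)N=C(N)N)cc(S(C)(=O)=O)c(Cl)c1[N+](=O)[O-]` differs from compound 3 by nitro in place of chloro on an aromatic carbon. Within the data shown here, no measured step exchanges a chloro for a nitro group, so the step from compound 1 to compound 2 bears on this only indirectly: it shows that one change at an aromatic carbon of this core can move the number a long way, but it gives no direction for a nitro group. With so little to go on, the expected step from compound 3 is a 1.7-fold higher number from compound 3 to compound 4 (0.24 log units; within the scatter), a modest weakening that may well fall within the scatter. Compound 4 is therefore estimated at 50 nM, expected to lie between 15 nM and 180 nM.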

Compound 4, half-maximal inhibitory concentration: 44 nM
Compound 4: middle estimate off by 1.1-fold (0.06 log units), on the high side; the measured number falls inside the stated range.
By their numbers in this assay, from the lowest: compounds 3, 1 and 4 (each within the scatter of the next); then compound 2.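

In this assay, putting nitro in place of chloro gives a 1.5-fold higher number from compound 3 to compound 4 (0.18 log units; within the scatter), so compound 3 and compound 4 cannot be told apart. At this aromatic carbon, ortho to a chloro group and ortho to a methyl group, a nitro group with 3 heavy atoms and 2 hydrogen-bond acceptors can therefore replace a single chlorine with no measurable cost, whereas a different exchange on an aromatic carbon gave a 14-fold higher number from compound 1 to compound 2 (1.16 log units; beyond the scatter). No independent measurement here explains why compound 3 and compound 4 read alike.

Going by these compounds, it remains open how an amine, a carboxylic acid or a longer chain at this position would read in this assay. Also open, on these data alone, is whether a nitro group would be accepted here without the neighbouring chloro and methyl groups.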